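Dipropylamino for dimethylamino: cytotoxicity expectation for compound 4

The compounds below may be only part of what the source reports. "The series", "measured", "known", "first", "only" and "open" are said of these compounds alone.

In an ADME assay on Vero cells (Chlorocebus sabaeus) for cytotoxicity, read by resazurin assay, with a stated time of 3 days (a higher number here means a weaker inhibitor, a lower number a stronger inhibitor), compound 1, `CCCN(CCC)c1cc2[nH]c(C3CCCCC3)nc2cc1NC(=O)c1ccccc1`, gives only a limit, > 100 ug/mL.
In this assay compound 2, `CCCCOC(=O)Nc1cc2nc(C3CCCCC3)[nH]c2cc1N(CCC)CCC`, likewise gives only a limit, > 100 ug/mL.
In this assay compound 3, `CN(C)c1cc2[nH]c(C3CCCCC3)nc2cc1NC(=O)OCc1ccccc1`, also gives only a limit, > 100 ug/mL.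

Compound 3 therefore stands at a limit and has no number of its own; every value shown sits at the limit of > 100 ug/mL in this assay, at which 3 of the 3 values shown sit. Compound 4, `CCCN(CCC)c1cc2[nH]c(C3CCCCC3)nc2cc1NC(=O)OCc1ccccc1`, differs from compound 3 by dipropylamino in place of dimethylamino on an aromatic carbon. Within the data shown here, no measured step covers this change. Among the measured compounds shown here, the only measured step, a step that the two limits leave unreadable from compound 1 to compound 2, concerns a different place and its size cannot be read, so it gives no guidance on direction. The step that the limit leaves unreadable from compound 3 to compound 4 is therefore expected to be none beyond the scatter. Compound 4 is estimated at 150 ug/mL, within 60 ug/mL to 400 ug/mL, most likely reported again as a limit.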

Compound 4, half-maximal inhibitory concentration: > 100 ug/mL
Compound 4 ended at the assay's limit; the forecaster's own chance of this, stated with the estimate: 75%; the middle value lies beyond the limit too.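

Among these compounds, no step between compound 1, compound 2, compound 3 and compound 4 can be read, because each gives only a limit: the limit of > 100 ug/mL in this assay, at which 4 of the 4 values shown sit.
The compounds shown leave open whether any of these group changes alters cytotoxicity, since none has a measured number.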